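This account rests on a few compounds, and the source may have more. Where it says the series, first, only, none or still open, it means among the compounds named here.

Measured so far in an assay for inhibition of Tryptophan 2,3-dioxygenase (Homo sapiens), with stated times of 10 min and 60 min, tested at 100 uM; a lower number here means a weaker effect, a higher number a stronger effect of the compound at the concentration tested:
compound 1 `N#Cc1cc(NCc2ccccc2[N+](=O)[O-])c2cn[nH]c2c1` gives 41%;
compound 2 `O=C(O)CNc1cccc(CNc2cc(C(F)(F)F)cc3[nH]ncc23)c1` gives 65%;
compound 3 `O=[N+](O)c1c(Cl)cccc1CNc1cc(C(F)(F)F)cc2[nH]ncc12` gives 94%.

Compound 2 holds the second highest of the three numbers in this assay. Its nearest neighbour is compound 1, whose number lies lower by a gap beyond the usual scatter; compound 3 is furthest, with a number higher by a gap also beyond the scatter.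

Compound 4 `CNC(=O)c1cccc(CNc2cc(C(F)(F)F)cc3[nH]ncc23)c1` is not yet measured. It differs from compound 2 in one place: methylcarbamoyl in place of (carboxymethyl)amino on an aromatic carbon. For the measured compounds named here, no step between two measured compounds covers this change, so its size has no direct precedent. In this assay only a modest step is expected, direction uncertain, quite possibly none beyond the scatter. Compound 4 is estimated at 60%, within 35% to 85%. This estimate implies a small step of a number 5 percentage points lower from compound 2 to compound 4 (within the scatter).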

Compound 4, a percentage reported as inhibition, at one concentration (the size of the read-out at that concentration, not a potency): 91%
Compound 4: the middle estimate sits 31 percentage points below what was measured; the whole stated range lies below it.
By their numbers in this assay, from the lowest: compound 1; then compound 2; then compounds 4 and 3 (each within the scatter of the next).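

In this assay, methylcarbamoyl in place of (carboxymethyl)amino on this aromatic carbon gives a number 26 percentage points higher from compound 2 to compound 4 (beyond the scatter). For the compounds shown here, this is the first single-place change, and it shows that the group on this carbon, meta to a large group, can by itself move the read-out beyond the scatter. Nothing at hand accounts for the step.

On these data alone, whether the gain is specific to methylcarbamoyl remains open, since an unsubstituted carbamoyl, ethylcarbamoyl or a simple amine on the same carbon could give a different read-out. As far as these compounds go, whether the same change carries over to another compound of the series also remains open.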